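The source may hold more compounds than are shown below. What is called first, only, known or untested is meant among the compounds shown, and "the series" means these compounds.

Measured so far:
- compound 1 `COc1cc(-c2nn(-c3cccc(NC(=O)c4cccc(C(F)(F)F)c4)c3)cc2-c2ccncc2)ccc1Cl` — 3240 nM
- compound 2 `COc1cc(-c2nn(-c3cccc(NC(=O)c4ccc(Cl)c(C(F)(F)F)c4)c3)cc2-c2ccncc2)ccc1Cl` — 20400 nM

In a functional assay on TK-10 cells (Homo sapiens) for inhibition, read by sulforhodamine B assay, with a stated time of 48 h (a lower number here means a stronger inhibitor of growth, a higher number a weaker inhibitor of growth), compound 2 stands highest of the two numbers; the nearest is compound 1, and the step of a 6.3-fold higher number from compound 1 to compound 2 (0.80 log units; beyond the scatter) lies beyond the scatter.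

Compound 3 `COc1cc(-c2nn(-c3cccc(NC(=O)c4ccccc4)c3)cc2-c2ccncc2)ccc1Cl` has not been measured. It differs from compound 2 by phenyl in place of 4-chloro-3-(trifluoromethyl)phenyl on a carbonyl carbon.

For the measured compounds named here, one measured step bears on this change: a 6.3-fold higher number from compound 1 to compound 2 (0.80 log units; beyond the scatter), where a chloro on that aryl group went with a higher number. Compound 3 reverses that chloro and also drops the trifluoromethyl, for which no step is shown. Compound 1 gives 3240 nM without the chloro, so a lower number than compound 2 is expected for compound 3, with the trifluoromethyl removal adding uncertainty. For compound 3 the estimate is 3500 nM (range 900 nM to 14000 nM), a step of a 5.8-fold lower number from compound 2 to compound 3 (0.77 log units; beyond the scatter).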

Compound 3, concentration for 50% growth inhibition: 7000 nM
Compound 3: middle estimate off by 2.0-fold (0.30 log units), on the low side, within the range that was stated.
By their numbers in this assay, from the lowest: compound 1; then compound 3; then compound 2.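

In this assay, the unsubstituted phenyl gives the series a reference point for the aryl group on the carbonyl carbon. Hydrogen in place of trifluoromethyl on an aromatic carbon gives a 2.2-fold higher number from compound 1 to compound 3 (0.33 log units; beyond the scatter), the first step to isolate that group, and trifluoromethyl goes with the lower number here, while phenyl in place of 4-chloro-3-(trifluoromethyl)phenyl gives a 2.9-fold lower number from compound 2 to compound 3 (0.46 log units; beyond the scatter), so the doubly substituted aryl group reads higher than phenyl despite the trifluoromethyl. Nothing measured here explains why these numbers move.

The compounds shown leave open how chloro alone on the phenyl would read, and so whether its step depends on the trifluoromethyl being present. Also open, from the compounds shown here alone, is how an amine, a carboxylic acid or a nitrile on that phenyl would read in this assay.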